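This account rests on a few compounds, and the source may have more. Where it says the series, first, only, none or still open, it means among the compounds named here.

Measured compounds in a functional assay on A2780 cells (Homo sapiens) for antiproliferative activity; a lower number here means a stronger inhibitor, a higher number a weaker inhibitor:
Compound 1 `Cc1ccccc1Nc1ncnn2ccc(CN3CCC(N)CC3)c12`: > 5000 nM, a limit of the assay.
Compound 2 `NC1CCN(Cc2ccn3ncnc(Nc4cccc(Br)c4)c23)CC1`: 2600 nM.

For the measured compounds named here, compound 2, at 2600 nM, holds the only true number so far in this assay. Compound 3 `COc1ccc(Nc2ncnn3ccc(CN4CCC(N)CC4)c23)cc1Cl` carries 3-chloro-4-methoxyphenyl in place of 3-bromophenyl on a nitrogen on an aromatic ring. Going by the values given here, the one measured step, an at least 1.9-fold lower number from compound 1 to compound 2 (0.28 log units; that floor lies within the scatter), also exchanges the group at that place, but it sets no direction for this change. No step beyond the scatter is therefore expected in this assay. The expected step is a 1.0-fold lower number from compound 2 to compound 3 (0.02 log units; within the scatter). Compound 3 is estimated at 2500 nM, with an expected range of 900 nM to 5000 nM.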

Compound 3, half-maximal inhibitory concentration: > 5000 nM
Compound 3: only a limit was reported; the forecaster's own chance of this, stated with the estimate: 25%; at least 2.0-fold (0.30 log units) between middle value and limit.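

In this assay compound 3, which carries 3-chloro-4-methoxyphenyl on a nitrogen on an aromatic ring, gives only a limit of the assay, > 5000 nM. Exchanging 3-bromophenyl for this group brings an at least 1.9-fold higher number from compound 2 to compound 3 (0.28 log units; that floor lies within the scatter), so this change shows no firm shift in either direction. The step from compound 1 to compound 3 cannot be read, and little can yet be said about this position: the limit of > 5000 nM in this assay, at which 2 of the 3 values shown sit.

From the compounds shown here alone, how far compound 3 truly lies from compound 2 stays open. So does whether a pyridyl group or a phenyl bearing an amine at this place would give a true number in this assay.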